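Flipping one stereocentre in a bromo-substituted enamine ester

The source may report more compounds than this note shows. Statements on the series, on what has been measured and on what is new or still open speak of the compounds shown alone.

Measured so far:
compound 1, `CCOC(=O)/C(C#N)=C(/NNC(=O)c1cc(OC)c(OC)c(OC)c1)N[C@H](C)c1ccccc1`, 25.1%;
compound 2, `CCOC(=O)/C(C#N)=C(/Nc1ccc(C(F)(F)F)cc1)N[C@@H](C)c1ccccc1`, 39.9%;
compound 3, `CCOC(=O)/C(C#N)=C(/Nc1ccc(Br)cc1)N[C@@H](C)c1ccccc1`, 19.3%.

In a functional assay on A-431 cells (Homo sapiens) for antiproliferative activity, read by MTT assay, with a stated time of 72 h, tested at 5 uM (a higher number here means more inhibition at the concentration tested (going by the name of the read-out), a lower number less inhibition), compound 3 has the smallest number of the three, though compound 1 sits within the scatter of it, and compound 2 stands well clear, as a number 20.6 percentage points lower from compound 2 to compound 3 (beyond the scatter) shows. Compound 4, `CCOC(=O)/C(C#N)=C(/Nc1ccc(Br)cc1)N[C@H](C)c1ccccc1`, differs from compound 3 only in configuration: the two compounds have the same atoms and bonds and differ only in configuration as drawn: 1 of 2 stereo elements differ; a stereocentre at a saturated chain carbon is drawn S in compound 3 and R in compound 4. Within the data shown here, the one step measured, the bromo-for-trifluoromethyl swap between compound 2 and compound 3, concerns a different part of the molecule and does not bear on a change of configuration; no pair differing only at this stereocentre has been measured. For compound 4 the expected step is therefore a number 0.3 percentage points lower from compound 3 to compound 4 (within the scatter), within the scatter. Compound 4 is thus estimated at 19%, ranging from 7% to 33%.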

Compound 4, a percentage reported as inhibition, at one concentration (the size of the read-out at that concentration, not a potency): 16.1%
Beside the measured number, compound 4's estimate is 2.9 percentage points above it, and the stated range covers the measured number.
By their numbers in this assay, from the lowest: compounds 4, 3 and 1 (each within the scatter of the next); then compound 2.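

Among these compounds, this is the first pair that isolates the stereocentre at the saturated chain carbon, and in this assay the step is a number 3.2 percentage points lower from compound 3 to compound 4 (within the scatter). With the bromo group present, this read-out at a single concentration does not tell the two configurations apart, and the comparison is a clean one: the fact that compounds 3 and 4 differ only in the configuration as drawn

Whether this holds with the trifluoromethyl group of compound 2 remains open, as this is the only such pair shown. Also open, on these data alone, is how a carboxylic acid in place of the ethyl ester would behave in either configuration.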